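Swapping pyridine for cyanothiophene on a high-clearance compound

This account rests on a few compounds, and the source may have more. Where it says the series, first, only, none or still open, it means among the compounds named here.

Measured in an in vitro ADME assay on microsomes from liver (Homo sapiens) for metabolic stability; on this read-out lower numbers stand for slow clearance and higher numbers for fast clearance:
compound 1 `O=C(COCc1ccncc1)N1CCN(c2ccc(Cl)cc2)CC1` gives 17 mL.min-1.g-1
compound 2 `O=C(COCc1cccnc1)N1CCN(c2ccc(Cl)cc2Cl)CC1` gives 210 mL.min-1.g-1

Of these two, compound 2 has the higher number at 210 mL.min-1.g-1, and the gap down to compound 1 at 17 mL.min-1.g-1 lies well beyond the usual scatter. The two differ in more than one place, so that gap cannot be tied to any single group.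

Compound 3 `N#Cc1ccc(COCC(=O)N2CCN(c3ccc(Cl)cc3Cl)CC2)s1` has 5-cyanothiophen-2-yl in place of pyridin-3-yl on a saturated chain carbon bound to an oxygen on a saturated carbon. Among the compounds with values here, no measured pair shows this change, so the expectation starts from compound 2 at 210 mL.min-1.g-1 and remains uncertain. The expected step of a 1.5-fold lower number from compound 2 to compound 3 (0.18 log units; within the scatter) is slightly downward and stays within the scatter. In this assay, compound 3 is estimated at 140 mL.min-1.g-1, with an expected range from 45 mL.min-1.g-1 to 400 mL.min-1.g-1.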

Compound 3, intrinsic clearance in microsomes: 110 mL.min-1.g-1
Compound 3: the middle estimate sits 1.3-fold (0.10 log units) above what was measured; the range from low to high includes it.
By their numbers in this assay, from the lowest: compound 1; then compounds 3 and 2 (each within the scatter of the next).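

Within the data shown here, this is the first pair here that differs in one place only, so a single change can be read: in this assay, putting 5-cyanothiophen-2-yl in place of pyridin-3-yl gives a 1.9-fold lower number from compound 2 to compound 3 (0.28 log units; within the scatter) and stays within the scatter. On this saturated chain carbon bound to an oxygen, then, a five-membered ring carrying a nitrile can take the place of the six-membered ring without a difference this assay can tell apart. Nothing measured here explains why the two compounds read alike.

As far as these compounds go, it remains open whether another group at this position, such as a carboxylic acid or an amine, would move the number beyond the scatter. Also open is which of the differences between compound 1 and compound 2 accounts for the wide gap between them.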